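The compounds below may be only part of what the source reports. "The series", "measured", "known", "first", "only" and "open" are said of these compounds alone.

Measured compounds:
compound 1, `COc1cc(C)cc(-c2nn(CC#N)cc2-c2ccc(-c3cccc(C(C)=O)c3)nc2)c1` — 92%
compound 2, `Cc1cc(O)cc(-c2nn(CC#N)cc2-c2ccnc(-c3ccc(Oc4ccccc4)cc3)c2)c1` — 91%

Both compounds were tested in a functional assay on SK-MEL-28 cells (Homo sapiens) for cytotoxicity, read by sulforhodamine B assay, with a stated time of 48 h, tested at 0.001 uM; a higher number here means a weaker effect of the compound at the concentration tested, a lower number a stronger effect. There compound 1 gives 92%, and compound 2 gives 91%. The gap between the two numbers is within the usual scatter of such measurements, so compound 2 cannot be told apart from compound 1; at this very low concentration both leave most of the cells growing.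

Compound 3, `Cc1cc(O)cc(-c2nn(CC#N)cc2-c2ccnc(-c3ccc(N(C)C)cc3)c2)c1`, has not yet been measured. It differs from compound 2 in a single place: dimethylamino in place of phenoxy on an aromatic carbon. Within the data shown here, no pair of measured compounds here shows what exchanging these two groups does, so no step in this assay can be read off from the numbers at hand. Given that compound 2 gives 91% and that both measured compounds cluster at nearly full cell survival, the step expected from compound 2 to compound 3 is a number 1 percentage points lower from compound 2 to compound 3 (within the scatter), that is, no change beyond the scatter. Compound 3 is therefore expected to give about 90% in this assay, with a plausible range from 78% to 100%.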

Compound 3, a percentage reported as activity, at one concentration (the size of the read-out at that concentration, not a potency): 102%
Beside the measured number, compound 3's estimate is 12 percentage points below it; measured number outside the range, above it.
By their numbers in this assay, from the lowest: compounds 2, 1 and 3 (each within the scatter of the next, the first and the last beyond it).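

In this assay, dimethylamino in place of phenoxy, on an aromatic carbon para to a large group, gives a number 11 percentage points higher from compound 2 to compound 3 (beyond the scatter), so the number at this very low concentration does respond to what sits at this position. The change takes away a six-membered aromatic ring of carbon only and goes from 7 heavy atoms to 3, swapping oxygen for nitrogen at the point of attachment while the count of hydrogen-bond acceptors stays the same, and this one pair cannot separate those differences from one another. Nothing at hand gives a reason for the step.

On these data alone, it remains open whether the higher number follows the loss of the ring or the arrival of the nitrogen: a methoxy group would keep the oxygen without the ring, and a piperidine would keep the nitrogen with a ring, though not an aromatic one. Because all of this rests on a single low concentration, the compounds shown also leave open how the two groups compare at higher concentrations, where a stronger effect on the cells might be seen.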